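This account rests on a few compounds, and the source may have more. Where it says the series, first, only, none or still open, it means among the compounds named here.

In a toxicity assay on NIH3T3 cells (Mus musculus) for cytotoxicity, read by resazurin assay (a higher number here means that more compound is needed for the effect, a lower number that less compound is needed), compound 1 (`COC(=O)c1ccc(NCc2cncn2Cc2ccc(N)cc2)cc1-c1ccccc1`) reads > 10000 nM as a limit, not a number. Compound 2 (`COC(=O)c1ccc(NCc2cncn2Cc2cccc(F)c2)cc1-c1ccccc1`) reads > 1000 nM as a limit as well. Compound 3 (`COC(=O)c1ccc(NCc2cncn2Cc2cccc(C)c2)cc1-c1ccccc1`) reads > 10000 nM as a limit too, so it stands on the limit of > 10000 nM in this assay, at which 2 of the 3 values shown sit, and has no number of its own.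

Compound 4 (`COC(=O)c1ccc(NCc2cncn2Cc2ccc(-c3ccccc3)cc2)cc1-c1ccccc1`) carries 4-phenylphenyl in place of 3-methylphenyl on a saturated chain carbon bound to an aromatic nitrogen. Two measured steps fall at that same place (a step that the two limits leave unreadable from compound 1 to compound 2 and a step that the two limits leave unreadable from compound 1 to compound 3). A third falls on an aromatic carbon (a step that the two limits leave unreadable from compound 2 to compound 3). Among the measured compounds shown here, none of the three has a readable size, so none gives a size to carry over to compound 4, and 4-phenylphenyl has no measured precedent.

In this assay, as far as these compounds go, no step beyond the scatter can be firmly expected, though a modest move toward less compound being needed stays open. Compound 4 is expected to report a limit rather than a number. The estimated step is small and leans to the lower side (an at least 1.2-fold lower number from compound 3 to compound 4 (0.09 log units; that floor lies within the scatter)). For compound 4 the estimated value is 8000 nM (expected range 2000 nM to 20000 nM).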

Compound 4, half-maximal effective concentration: > 1000 nM
Compound 4: a limit, no number; the forecaster's own chance of this, stated with the estimate: 75%; the middle value does not contradict the limit.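

In this assay compound 4 gives > 1000 nM as a limit, not a number. The steps from compound 1, compound 2 and compound 3 to compound 4 cannot be read, as all four values are limits. The compounds shown leave open where any half-maximal effective concentration lies, and whether the group on the saturated chain carbon changes it.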